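A few compounds are considered here, and "the series" means these few. Any claim that something is new, unique, unknown or untested is made for them only; others in the source may bear on it.

Of the compounds shown here, three sharing one core have been tested in a functional assay on HUVEC cells (Homo sapiens) for inhibition, tested at 10 ug/mL; a higher number here means a stronger effect of the compound at the concentration tested, a lower number a weaker effect. Compound 1 `COc1cc(/C=C/C(=O)c2cccc(NC(=O)c3ccc(Cl)cc3)c2)ccc1O` gives 66%, compound 2 `COc1cc(/C=C/C(=O)c2cccc(NC(=O)c3ccc(Cl)c(Cl)c3)c2)ccc1O` gives 45%, and compound 3 `COC(=O)C(=O)Nc1cccc(C(=O)/C=C/c2ccc(O)c(OC)c2)c1` gives 43%. Compound 3 thus holds the lowest of the three numbers, though its gap to compound 2 lies within the scatter, while its gap to compound 1 lies beyond it. The measured steps are a number 21 percentage points lower from compound 1 to compound 2 (beyond the scatter), a number 23 percentage points lower from compound 1 to compound 3 (beyond the scatter) and a number 2 percentage points lower from compound 2 to compound 3 (within the scatter).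

Compound 4 `CCCC(=O)Nc1cccc(C(=O)/C=C/c2ccc(O)c(OC)c2)c1` has not yet been measured. It differs from compound 3 in one place: propyl in place of methoxycarbonyl on a carbonyl carbon. Among the compounds with values here, the steps that bear on this change are those that altered the group on the same carbonyl carbon, namely a number 23 percentage points lower from compound 1 to compound 3 (beyond the scatter) and a number 2 percentage points lower from compound 2 to compound 3 (within the scatter). Within the data shown here, both set methoxycarbonyl on that carbon in place of the groups carried by compound 1 and compound 2; no measured pair shows propyl there, so the direction is uncertain. The expected step is a number 2 percentage points higher from compound 3 to compound 4 (within the scatter), not beyond the scatter. Compound 4 is estimated at 45%, within 25% to 65%.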

Compound 4, a percentage reported as inhibition, at one concentration (the size of the read-out at that concentration, not a potency): 87%
For compound 4 the middle estimate is 42 percentage points below the measured one, outside the stated range (above it).
By their numbers in this assay, from the lowest: compounds 3 and 2 (each within the scatter of the next); then compound 1; then compound 4.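

In this assay, within the data shown here, the group on the carbonyl carbon whose other neighbour is the amide-type nitrogen proves able to lift the read-out well past anything the earlier compounds reached: propyl in place of methoxycarbonyl gives a number 44 percentage points higher from compound 3 to compound 4 (beyond the scatter) and propyl in place of 3,4-dichlorophenyl gives a number 42 percentage points higher from compound 2 to compound 4 (beyond the scatter) in the same assay. Propyl also exceeds 4-chlorophenyl, the best group until now, with a number 21 percentage points higher from compound 1 to compound 4 (beyond the scatter) here, so an aromatic ring on this carbon is not required for a strong effect at the concentration tested. No measurement available here explains this gain.

Going by these compounds, whether the gain is specific to propyl remains open, since a shorter ethyl chain, a longer butyl chain or a branched isopropyl group could behave differently. An amine or a carboxylic acid at the same place is equally uncharted.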